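Isopropylsulfamoyl in place of cyclobutylsulfonyl on compound 2

This account rests on a few compounds, and the source may have more. Where it says the series, first, only, none or still open, it means among the compounds named here.

Among the compounds with values here, compound 2 `CC(C)c1noc(N2CCN(C(=O)[C@@H]3CCCN(S(=O)(=O)c4ccc(S(=O)(=O)C5CCC5)cc4)C3)CC2)n1` holds the lower of the two numbers measured so far: in a functional assay on MIA PaCa-2 cells (Homo sapiens) for inhibition, read by MTT assay, with a stated time of 7 days (on this read-out lower numbers stand for stronger inhibition and higher numbers for weaker inhibition), compound 2 gives 70 nM. Compound 1 `CCCN(CCC)S(=O)(=O)c1ccc(S(=O)(=O)N2CCC[C@@H](C(=O)OCC)C2)cc1` is the only other point, and in this assay compound 1 gives 2300 nM, a far higher number, though the two structures differ in several places at once. Compound 3 `CC(C)NS(=O)(=O)c1ccc(S(=O)(=O)N2CCC[C@@H](C(=O)N3CCN(c4nc(C(C)C)no4)CC3)C2)cc1` keeps the core of compound 2 and carries isopropylamino in place of cyclobutyl on a sulfonyl sulfur. Within the data shown here, no measured pair shows this exchange alone, so only a small shift, if any, is expected, with a slight loss somewhat more likely than a gain. The step expected is a 1.7-fold higher number from compound 2 to compound 3 (0.23 log units; within the scatter). Compound 3 is estimated at 120 nM, within a range from 40 nM to 400 nM.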

Compound 3, half-maximal inhibitory concentration: 2600 nM
Beside the measured number, compound 3's estimate is 22-fold (1.34 log units) below it, outside the stated range (above it).
By their numbers in this assay, from the lowest: compound 2; then compounds 1 and 3 (each within the scatter of the next).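

In this assay, isopropylamino in place of cyclobutyl on a sulfonyl sulfur, with the rest of the structure unchanged, brings a 37-fold higher number from compound 2 to compound 3 (1.57 log units; beyond the scatter), so the group at this place strongly affects the read-out. The exchange removes a four-membered ring and adds a hydrogen-bond donor while leaving the heavy-atom count unchanged, and this one step cannot separate those two differences. No measurement here accounts for the loss.

Going by these compounds, it remains open whether the ring or the nitrogen matters more. Cyclobutylamino, which keeps the ring and adds the nitrogen, and isopropyl, which lacks both, could separate them.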